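N-Methylation of a Sulfonamide in a Biphenyltetrazole Series

The compounds below may be only part of what the source reports. "The series", "measured", "known", "first", "only" and "open" are said of these compounds alone.

Measured so far:
compound 1, `CCCCc1ccc(CNC(=O)Nc2ccccc2)c(=O)n1Cc1ccc(-c2ccccc2-c2nn[nH]n2)cc1`: 30 nM
compound 2, `CCCCc1ccc(CNS(=O)(=O)c2ccccc2)c(=O)n1Cc1ccc(-c2ccccc2-c2nn[nH]n2)cc1`: 7 nM

The account concerns a functional assay (aorta) for antagonist activity, with Oryctolagus cuniculus as the target; a higher number here means a weaker inhibitor, a lower number a stronger inhibitor. Compound 2 holds the lowest of the two numbers; its nearest neighbour is compound 1, and the step of a 4.3-fold lower number from compound 1 to compound 2 (0.63 log units; beyond the scatter) is the only measured one, a modest change beyond the scatter.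

Compound 3, `CCCCc1ccc(CN(C)S(=O)(=O)c2ccccc2)c(=O)n1Cc1ccc(-c2ccccc2-c2nn[nH]n2)cc1`, has not yet been measured. It differs from compound 2 by methyl in place of hydrogen on a sulfonamide nitrogen. Going by the values given here, the single measured step, a 4.3-fold lower number from compound 1 to compound 2 (0.63 log units; beyond the scatter), concerns the exchange of a carbamoyl for a sulfonyl group and does not touch this nitrogen's substituent, so no measured step bears directly on the change. The expectation is therefore a step of a 1.4-fold higher number from compound 2 to compound 3 (0.15 log units; within the scatter), within the scatter in either direction. Compound 3 is estimated at 10 nM, with a range from 3 nM to 40 nM.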

Compound 3, half-maximal inhibitory concentration: 2 nM
Compound 3: the middle estimate sits 5.0-fold (0.70 log units) above what was measured, outside the stated range (below it).
By their numbers in this assay, from the lowest: compound 3; then compound 2; then compound 1.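

In this assay, the sulfonamide nitrogen proves to be a position where the hydrogen can be given up: methyl in its place produces a 3.5-fold lower number from compound 2 to compound 3 (0.54 log units; beyond the scatter) and so carries the series further than the sulfonyl exchange alone. Taken as one replacement on the saturated chain carbon, methyl(phenylsulfonyl)amino in place of (phenylcarbamoyl)amino gives a 15-fold lower number from compound 1 to compound 3 (1.18 log units; beyond the scatter) and is the largest step among these compounds, leaving compound 3 with the lowest number, beyond the scatter from both others. Nothing available explains why this methyl lowers the number.

Going by these compounds, whether an ethyl group or a longer chain on this nitrogen would lower the number further or reverse the step stays open. On these data alone, it is also open whether methyl on the corresponding nitrogen of compound 1 would give a similar step.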